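This account rests on a few compounds, and the source may have more. Where it says the series, first, only, none or still open, it means among the compounds named here.

Measured compounds:
Compound 1 `O=C(NCCCCN1CCN(c2ccc(Cl)cc2)CC1)c1ccc(-c2ccsc2)cc1`: 0.837 h
Compound 2 `COc1ccccc1N1CCN(CCCCNC(=O)c2ccc(-c3ccsc3)cc2)CC1`: 0.04 h
Compound 3 `N#Cc1cccc(N2CCN(CCCCNC(=O)c3ccc(-c4ccsc4)cc3)CC2)c1`: > 1 h (a limit of the assay)

In an ADME assay on microsomes from liver (Rattus norvegicus) for metabolic stability, read by LC-MS, using NADPH (on this read-out lower numbers stand for a shorter-lived compound and higher numbers for a longer-lived compound), compound 1 gives 0.837 h. Compound 2 gives 0.04 h. Compound 3 reaches only the limit of the assay, > 1 h, so for compound 3 there is no number, only that limit, which is the limit of > 1 h in this assay, at which 1 of the 3 values shown sits. On the numbers shown compound 3 stands at the long-lived end: the step of an at least 25-fold higher number from compound 2 to compound 3 (1.39 log units; beyond the scatter) is large, while the step of an at least 1.1-fold higher number from compound 1 to compound 3 (0.07 log units; that floor lies within the scatter) lies within the scatter.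

Compound 4 `O=C(NCCCCN1CCN(c2ccccc2C(F)(F)F)CC1)c1ccc(-c2ccsc2)cc1` differs from compound 3 by 2-(trifluoromethyl)phenyl in place of 3-cyanophenyl on an amine nitrogen in a ring. Both steps that change the group on the ring nitrogen bear on it. The step of a 21-fold lower number from compound 1 to compound 2 (1.32 log units; beyond the scatter) is large and downward, and so is the reverse of the step from compound 2 to compound 3, whereas the step of an at least 1.1-fold higher number from compound 1 to compound 3 (0.07 log units; that floor lies within the scatter) is small. Two of the three measured groups on this ring nitrogen leave the half-life long; one, in compound 2, leaves it very short. Compound 4 carries a group seen nowhere among the measured compounds, so a step in this assay of size an at least 2.0-fold lower number from compound 3 to compound 4 (0.30 log units; that floor lies within the scatter) is expected, with wide uncertainty. For compound 4 a half-life of 0.5 h is estimated, between 0.08 h and 1.5 h.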

Compound 4, half-life: 0.0667 h
Compound 4: middle estimate off by 7.5-fold (0.87 log units), on the high side; measured number outside the range, below it.
By their numbers in this assay, from the lowest: compounds 2 and 4 (each within the scatter of the next); then compound 1. At a limit, above all of these: compound 3.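

The half-lives of compound 2 and compound 4 cannot be told apart in this assay, the step being a 1.7-fold higher number from compound 2 to compound 4 (0.22 log units; within the scatter), so a short half-life is no longer tied to the methoxy of compound 2 alone. The 2-(trifluoromethyl)phenyl of compound 4 falls well short of the other two groups, with a 13-fold lower number from compound 1 to compound 4 (1.10 log units; beyond the scatter) and an at least 14-fold lower number from compound 3 to compound 4 (1.17 log units; beyond the scatter), so that among these four compounds the 2-methoxyphenyl and 2-(trifluoromethyl)phenyl groups give the short half-lives, the 4-chlorophenyl and 3-cyanophenyl groups give the longer ones, and no compound goes against this. The last of those steps is only a floor, since compound 3 sits at a limit of the assay: the limit of > 1 h in this assay, at which 1 of the 4 values shown sits.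

The compounds shown leave open whether the place of the group on the phenyl or the group itself goes with the short half-life, as no group appears at two different places on that ring. A 4-methoxyphenyl or a 3-(trifluoromethyl)phenyl on the ring nitrogen would separate the two readings, and a plain phenyl there would give the comparison that all four compounds lack.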